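Swapping a bulky tert-butyl arene for a chloro arene

A few compounds are considered here, and "the series" means these few. Any claim that something is new, unique, unknown or untested is made for them only; others in the source may bear on it.

Compound 2 `COc1cc2ncnc(Nc3ccc(NC(=O)c4ccc(C(C)(C)C)cc4)cc3)c2cc1OC` carries a 4-(tert-butyl)phenyl on its amide carbonyl. In a functional assay on HepG2 cells (Homo sapiens) for inhibition, read by MTT assay (on this read-out lower numbers stand for stronger inhibition and higher numbers for weaker inhibition), compound 2 reaches only the assay limit, > 100000 nM, so no number is known for it. Compound 4 `COc1cc2ncnc(Nc3ccc(NC(=O)c4cccc(Cl)c4)cc3)c2cc1OC` differs in one place: 3-chlorophenyl in place of 4-(tert-butyl)phenyl on a carbonyl carbon. Going by the values given here, two measured steps bear on this. From the methyl analogue compound 1 `COc1cc2ncnc(Nc3ccc(NC(=O)c4ccc(C)cc4)cc3)c2cc1OC`, which gives 25000 nM, the step of an at least 4.0-fold higher number from compound 1 to compound 2 (0.60 log units; beyond the scatter) was seen. Toward the fluoro analogue compound 3 `COc1cc2ncnc(Nc3ccc(NC(=O)c4ccccc4F)cc3)c2cc1OC`, which gives 13000 nM, the step of an at least 7.6-fold lower number from compound 2 to compound 3 (0.88 log units; beyond the scatter) was seen. Both show the tert-butyl compound at the weak end, so compound 4 is expected to move in the same direction as compound 3, a step of about an at least 5.0-fold lower number from compound 2 to compound 4 (0.69 log units; beyond the scatter). Compound 4 is estimated at 20000 nM, between 7000 nM and 60000 nM.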

Compound 4, half-maximal inhibitory concentration: 12000 nM
For compound 4 the middle estimate is 1.7-fold (0.22 log units) above the measured one; the range from low to high includes it.
By their numbers in this assay, from the lowest: compounds 4, 3 and 1 (each within the scatter of the next, the first and the last beyond it). At a limit, above all of these: compound 2.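

In this assay, placing 3-chlorophenyl on the carbonyl carbon gives an at least 8.3-fold lower number from compound 2 to compound 4 (0.92 log units; beyond the scatter). Compound 2 is held at a limit and not at a number: the limit of > 100000 nM in this assay, at which 1 of the 4 values shown sits. Going by these compounds alone, the other steps separate the remaining compounds: a 1.1-fold lower number from compound 3 to compound 4 (0.03 log units; within the scatter) leaves compound 3 and compound 4 level, while a 2.1-fold lower number from compound 1 to compound 4 (0.32 log units; beyond the scatter) is the first modest gain over compound 1 that exceeds the scatter.

From the compounds shown here alone, whether the chlorine itself matters, or where it sits on the ring, stays open. So does the effect of an amine or a carboxylic acid on this ring.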